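Reshaping the imidazole arm of compound 2

The source may hold more compounds than are shown below. What is called first, only, known or untested is meant among the compounds shown, and "the series" means these compounds.

Within the data shown here, compound 2 `CCn1cc(CN2CCN(c3cccc4[nH]c(-c5ccc(C(C)(C)C)cc5)nc34)CC2)nc1C` holds the lowest of the two numbers known in an assay on isolated protein for displacement of a labelled ligand from Gonadotropin-releasing hormone receptor (Rattus norvegicus) (a lower number here means a stronger inhibitor, a higher number a weaker inhibitor), where compound 2 gives 51 nM. Its nearest neighbour is compound 1 `Cc1nc(C)c(CN2CCN(c3cccc4[nH]c(-c5ccc(C(C)(C)C)cc5)nc34)CC2)o1`, which in this assay gives 740 nM; the change was a 15-fold lower number from compound 1 to compound 2 (1.16 log units; beyond the scatter), obtained by exchanging one five-membered azole for another at the same place. Compound 3 `CCCn1c(CC)nc(C)c1CN1CCN(c2cccc3[nH]c(-c4ccc(C(C)(C)C)cc4)nc23)CC1` differs from compound 2 by 2-ethyl-4-methyl-1-propyl-1H-imidazol-5-yl in place of 1-ethyl-2-methyl-1H-imidazol-4-yl on a saturated chain carbon bound to an amine nitrogen in a ring. This time the ring type is kept; what changes is the set of substituents on the imidazole and the ring atom through which it is joined to the methylene. Among the measured compounds shown here, none of the measured steps covers such a rearrangement; the single known step only shows that this part of the molecule is sensitive, and it does so for a different kind of change. For the measured compounds named here, with no comparable precedent, compound 3 is expected to stay close to compound 2, the estimated step being a 1.2-fold higher number from compound 2 to compound 3 (0.07 log units; within the scatter) and within the scatter. The estimate for compound 3 in this assay is 60 nM, with a range from 15 nM to 250 nM.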

Compound 3, half-maximal inhibitory concentration: 120 nM
Beside the measured number, compound 3's estimate is 2.0-fold (0.30 log units) below it, and the stated range covers the measured number.
By their numbers in this assay, from the lowest: compound 2; then compound 3; then compound 1.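

In this assay the position proves to accept a substantial reshaping of the imidazole at a modest cost: the result is a 2.4-fold higher number from compound 2 to compound 3 (0.37 log units; beyond the scatter) and so lies beyond the scatter, even though 2-ethyl-4-methyl-1-propyl-1H-imidazol-5-yl carries 11 heavy atoms against 8 in the group it replaces. The ring type therefore matters more here than the exact decoration of the imidazole, at least among these three compounds, since the change to this second imidazole still gives a 6.2-fold lower number from compound 1 to compound 3 (0.79 log units; beyond the scatter) and leaves both imidazoles on the stronger side of the oxazole. Nothing given here accounts for either step.

The change in the ring atom joined to the methylene and the changes in the substituents arrive together in compound 3, so the compounds shown leave open which of them produces the loss. Also open, from the compounds shown here alone, is whether a 1-methyl group in place of the 1-propyl, or an imidazole bearing an amine or a carboxylic acid on a longer chain, would hold the number near that of compound 2.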